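This account rests on a few compounds, and the source may have more. Where it says the series, first, only, none or still open, it means among the compounds named here.

In an ADME assay on MT4 cells (Homo sapiens) for cytotoxicity, with a stated time of 5 days (a lower number here means that less compound is tolerated, a higher number that more compound is tolerated), compound 3 (`CC(C)(C)C#Cc1cc(N(CCO)C(=O)[C@H]2CC[C@H](C)CC2)c(C(=O)O)s1`) gives > 20000 nM as its reading, which is a limit and not a number. Its place is therefore shared rather than ranked. Compound 1 (`CC(C)(C)C#Cc1cc(N(C(=O)[C@H]2CC[C@H](C)CC2)[C@H]2C[C@@H](Oc3cccnc3)C2)c(C(=O)O)s1`) reads > 20000 nM in this assay, also a limit. Compound 2 (`CON=C1CCC(N(c2cc(C#CC(C)(C)C)sc2C(=O)O)C(=O)[C@H]2CC[C@H](C)CC2)CC1`) reads > 20000 nM there, again a limit. Going by the values given here, the whole series so far comes down to the limit of > 20000 nM in this assay, at which 3 of the 3 values shown sit, and nothing finer.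

The change to compound 4 (`CC(C)(C)C#Cc1cc(N(C(=O)[C@H]2CC[C@H](C)CC2)[C@H]2CC[C@H](Oc3nccs3)CC2)c(C(=O)O)s1`) puts 4-((1,3-thiazol-2-yl)oxy)cyclohexyl in place of 2-hydroxyethyl on an amide-type nitrogen.

Among the compounds with values here, three measured steps touch this position: a step that the two limits leave unreadable from compound 1 to compound 3, a step that the two limits leave unreadable from compound 2 to compound 3 and a step that the two limits leave unreadable from compound 1 to compound 2. None of them gives a size, but swapping quite different groups on that nitrogen has not yet brought any compound off the limit. The nearest comparison is compound 1, which carries 3-((pyridin-3-yl)oxy)cyclobutyl on that nitrogen and still shows > 20000 nM as a limit.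

The expected outcome for this change is a number no higher from compound 3 to compound 4 (the limit leaves the size open) in size, with no direction expected beyond the scatter. A reported limit is the likeliest result, though a measurable number remains possible. Compound 4 is estimated at 20000 nM in this assay, with an expected range of 10000 nM to 30000 nM around that estimate.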

Compound 4, half-maximal cytotoxic concentration: > 20000 nM
Compound 4 ended at the assay's limit (the forecaster's own chance of this, stated with the estimate: 80%); the middle value sits exactly at the limit.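

Compound 4 reads > 20000 nM, which is a limit, so none of its steps from compound 1, compound 2 or compound 3 can be read. The compounds shown leave open whether any group on that amide-type nitrogen would give a measurable number in this assay, since the series still rests on one reading: the limit of > 20000 nM in this assay, at which 4 of the 4 values shown sit.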